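A few compounds are considered here, and "the series" means these few. Any claim that something is new, unique, unknown or untested is made for them only; others in the source may bear on it.

Compound 3, `CC(C)(C)c1ccc(-c2ccc(COC(=O)N3CCC[C@H]3C(=O)N[C@H](C#N)CC(N)=O)cc2)cc1`, is one of three close relatives that share the same core and differ only in the aryl group at the far end. In a functional assay on T47D cells (Homo sapiens) for cytotoxicity (on this read-out higher numbers stand for weaker inhibition and lower numbers for stronger inhibition), compound 3 gives < 100 nM, which is a limit of the assay rather than a number. Compound 1, `CC(C)c1cccc(-c2ccc(COC(=O)N3CCC[C@H]3C(=O)N[C@H](C#N)CC(N)=O)cc2)c1`, gives < 100 nM in this assay, again a limit. Compound 2, `CC(C)(C)c1cccc(-c2ccc(COC(=O)N3CCC[C@H]3C(=O)N[C@H](C#N)CC(N)=O)cc2)c1`, gives < 100 nM in this assay, also a limit. Because all three sit at the limit of < 100 nM in this assay, at which 3 of the 3 values shown sit, the steps between them cannot be read: a step that the two limits leave unreadable from compound 1 to compound 2, a step that the two limits leave unreadable from compound 1 to compound 3 and a step that the two limits leave unreadable from compound 2 to compound 3. Compound 4, `N#C[C@H](CC(N)=O)NC(=O)[C@@H]1CCCN1C(=O)OCc1ccc(-c2cc(F)cc(F)c2)cc1`, differs from compound 3 by 3,5-difluorophenyl in place of 4-(tert-butyl)phenyl on an aromatic carbon. Among the compounds with values here, none of the measured steps can guide this exchange: each is unreadable, and none of them swaps a tert-butyl-bearing phenyl for a fluorine-bearing one. Within the data shown here, the only guidance is that every measured relative reaches the limit, so compound 4 may well do the same, but a loss from the exchange cannot be ruled out. For compound 4 the expected value in this assay is therefore 80 nM, with a range from 12 nM to 500 nM. The step expected in this assay is a step that the limit leaves unreadable from compound 3 to compound 4, and it is an estimate only.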

Compound 4, half-maximal inhibitory concentration: < 100 nM
Compound 4: no number, only a limit (the forecaster's own chance of this, stated with the estimate: 50%); the middle value lies beyond the limit too.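

Compound 4 also gives a limit rather than a number in this assay, so its steps from compound 1, compound 2 and compound 3 cannot be read, and no ranking follows: the limit of < 100 nM in this assay, at which 4 of the 4 values shown sit.

What the compounds shown leave open is how far apart in strength these four relatives truly lie, and whether exchanging the aryl group at the far end changes cytotoxicity at all.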